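Working notes on the step from compound 3 to compound 4

The compounds below may be only part of what the source reports. "The series", "measured", "known", "first", "only" and "open" are said of these compounds alone.

Measured so far in a physicochemical assay for lipophilicity, read by HPLC, at pH 7.4; on this read-out lower numbers stand for lower lipophilicity and higher numbers for higher lipophilicity (three compounds):
- compound 1 `O=C(O)CCn1c(=O)oc2cc(OCC3CCC3)c(Cl)cc21` with 2.9
- compound 2 `O=C(O)CCn1c(=O)oc2cc(OCc3ccccc3)c(Cl)cc21` with 2.71
- compound 3 `C[C@@H](Oc1cc2oc(=O)n(CCC(=O)O)c2cc1Cl)c1ccc(Cl)cn1` with 2.65

The number for compound 3 cannot be told apart from those of compound 1 and compound 2, since all three lie within the usual scatter of one another.

Compound 4 `C[C@@H](Oc1cc2oc(=O)n(CCC(=O)O)c2cc1Cl)c1ncccn1` has not been measured. It carries pyrimidin-2-yl in place of 5-chloropyridin-2-yl on a saturated chain carbon bound to an oxygen on an aromatic ring and a saturated chain carbon.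

Within the data shown here, only one measured step bears on this, and only loosely. That step is a number 0.19 log units lower from compound 1 to compound 2 (within the scatter) and it puts phenyl in place of cyclobutyl on a saturated chain carbon bound to an oxygen on an aromatic ring. It is a swap at a comparable place, but it does not remove a chlorine or add a hetero atom, so the data give no direct measure of this change. The size and direction expected here therefore rest mainly on the structural change itself, and they are uncertain. In this assay the expected change is a number 1.05 log units lower from compound 3 to compound 4 (beyond the scatter) and this would lie beyond the scatter. In this assay compound 4 is estimated at 1.6 with a range from 1.2 to 2 expected.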

Compound 4, distribution coefficient: 0.83
For compound 4 the middle estimate is 0.77 log units above the measured one; measured number outside the range, below it.
By their numbers in this assay, from the lowest: compound 4; then compounds 3, 2 and 1 (each within the scatter of the next).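

In this assay this position turns out to be highly responsive: pyrimidin-2-yl in place of 5-chloropyridin-2-yl on a saturated chain carbon bound to an oxygen on an aromatic ring and a saturated chain carbon gives a number 1.82 log units lower from compound 3 to compound 4 (beyond the scatter), whereas the groups in compounds 1, 2 and 3 all read within the scatter of one another. The broader swaps on the oxygen on an aromatic ring agree, with a number 1.88 log units lower from compound 2 to compound 4 (beyond the scatter) and a number 2.07 log units lower from compound 1 to compound 4 (beyond the scatter), so compound 4 stands apart from all three earlier compounds, and the change of group at this place can move the number far beyond the scatter. No supporting measurement is available to explain the size of this step.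

The step from compound 3 to compound 4 combines the loss of the chlorine with a second ring nitrogen, and the compounds shown leave open how much of it goes with each, which a plain pyridin-2-yl group at this place would help to separate. Also open, from the compounds shown here alone, is how the number would respond to a ring bearing an amine or a methoxy group here.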